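Fluoro for Chloro on the Shared Core

This account rests on a few compounds, and the source may have more. Where it says the series, first, only, none or still open, it means among the compounds named here.

Of the compounds shown here, three carrying the same core have been measured in an assay on isolated protein for displacement of a labelled ligand from metabotropic glutamate receptor 5 (Homo sapiens), with a stated time of 60 min, tested at 1 uM; on this read-out lower numbers stand for less inhibition and higher numbers for more inhibition at the one concentration tested (going by the name of the read-out). Compound 1 `Cc1ccc(S(=O)(=O)c2cnc3ccc(F)cc3c2N2CCC(C)CC2)cc1` gives 91% in this assay, compound 2 `COc1ccc(S(=O)(=O)c2cnc3ccc(F)cc3c2N2CCC(C)CC2)cc1` gives 85%, and compound 3 `CC1CCN(c2c(S(=O)(=O)c3cc(Cl)cc(Cl)c3)cnc3ccc(Cl)cc23)CC1` gives 88%. Among the measured compounds shown here, the one step between measured compounds that differs in a single place is a number 6 percentage points lower from compound 1 to compound 2 (within the scatter), which stays within the scatter. Compound 3 stands alongside the other two: the gap to compound 1 and the gap to compound 2 are both within the scatter, so none of the three can be set apart from the others.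

Compound 4 `CC1CCN(c2c(S(=O)(=O)c3cc(Cl)cc(Cl)c3)cnc3ccc(F)cc23)CC1` has not yet been measured. It differs from compound 3 in one place: fluoro in place of chloro on an aromatic carbon. For the measured compounds named here, no measured step of this kind exists among the three compounds, so the expectation rests on what the measured compounds show. Compound 1 and compound 2 both carry fluoro at this place of the core. Compound 1 gives 91%. Compound 2 gives 85%. Both numbers sit close to that of compound 3, which carries chloro there and gives 88%. On this basis compound 4 is expected to show a step of no change at the digits printed from compound 3 to compound 4 (within the scatter), that is, no change beyond the scatter. The estimate for compound 4 in this assay is 88%, with a range from 78% to 96%.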

Compound 4, a percentage reported as inhibition, at one concentration (the size of the read-out at that concentration, not a potency): 69%
Estimate against measurement, compound 4: 19 percentage points above, outside the stated range (below it).
By their numbers in this assay, from the lowest: compound 4; then compounds 2, 3 and 1 (each within the scatter of the next).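

The chloro-to-fluoro change on the aromatic carbon of the shared core gives a number 19 percentage points lower from compound 3 to compound 4 (beyond the scatter) in this assay, so with 3,5-dichlorophenyl on the sulfonyl sulfur this place does not treat the two halogens alike. With fluoro held at this place, the group on the sulfonyl sulfur also matters, as seen in a number 16 percentage points lower from compound 2 to compound 4 (beyond the scatter) and in a number 22 percentage points lower from compound 1 to compound 4 (beyond the scatter), whereas the earlier step between the 4-methylphenyl and 4-methoxyphenyl compounds, a number 6 percentage points lower from compound 1 to compound 2 (within the scatter), gave no sign of this. Fluoro on the core therefore goes with a high number alongside 4-methylphenyl or 4-methoxyphenyl and with a clearly lower one alongside 3,5-dichlorophenyl, while no evidence at hand speaks to what lies behind this drop.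

The compounds shown leave open whether chloro at this place would keep the numbers of the fluoro compounds when paired with 4-methylphenyl or 4-methoxyphenyl, so the halogen step can be read on one sulfonyl group only. They also leave open how a nitrile or a methyl at this place of the core would compare, and whether a single chloro on the phenyl at the sulfonyl sulfur would behave like 3,5-dichlorophenyl.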